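The compounds below may be only part of what the source reports. "The series", "measured", "known", "first", "only" and "open" are said of these compounds alone.

In an in vitro functional assay on 1321-N1 cells for agonist activity at P2Y purinoceptor 2 (Homo sapiens), read by scintillation proximity assay and inositol phosphate accumulation (on this read-out higher numbers stand for an effect only at larger amounts of compound and lower numbers for an effect already at smaller amounts), compound 1 `Nc1nc(=O)ccn1[C@@H]1O[C@H](COP(=O)(O)OP(=O)(O)O)[C@@H](O)[C@H]1O` gives 604 nM. Compound 2 `CNc1nc(=O)ccn1[C@@H]1O[C@H](COP(=O)(O)O)[C@@H](O)[C@H]1O` is a different case: in this assay compound 2 gives > 100000 nM, which is a limit of the assay and not a number. The path to compound 3 `Nc1nc(=O)ccn1[C@@H]1O[C@H](COP(=O)(O)O)[C@@H](O)[C@H]1O` is a small change on paper: hydrogen in place of methyl on a nitrogen on an aromatic ring. Among the measured compounds shown here, since compound 2 sits at the limit of > 100000 nM in this assay, at which 1 of the 2 values shown sits, no measured step shows how this change acts, and the gap to compound 1 tells no more than the two values themselves. Compound 3 is expected to stay weak, with an expected step of an at least 2.0-fold lower number from compound 2 to compound 3 (0.30 log units; that floor lies within the scatter) that cannot be set against the scatter while the starting point is a limit. The estimate for compound 3 in this assay is 50000 nM, with a range from 10000 nM to 300000 nM, and a fair chance that the assay again reports a limit rather than a number.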

Compound 3, half-maximal effective concentration: > 100000 nM
Compound 3 gave a limit, no number (the forecaster's own chance of this, stated with the estimate: 55%); at least 2.0-fold (0.30 log units) between middle value and limit.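

Going from methylamino to amino leaves compound 3 at a limit of the assay, as compound 2 was, and the step between these two cannot be read, which leaves the effect of this change on the nitrogen unknown. The new information comes from a different place: in this assay, the loss of a group of 4 heavy atoms (3 oxygen, 1 phosphorus) from an oxygen of compound 1 gives an at least 160-fold higher number from compound 1 to compound 3 (2.21 log units; beyond the scatter). Most of the values shown now sit at the end of the measurable range: the limit of > 100000 nM in this assay, at which 2 of the 3 values shown sit.

Open, going by these compounds, is what methylamino would do on compound 1, which keeps that phosphorus-bearing group and gives a readable number. Also open, on these data alone, is how an ethyl group on that nitrogen, or a further phosphate on the chain, would read.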